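Swapping an aromatic amide for an isopropyl amide

The compounds below may be only part of what the source reports. "The series", "measured", "known", "first", "only" and "open" are said of these compounds alone.

Measured so far:
- compound 1, `COc1ccc(C(=O)N2CCN(Cc3nc4ccccc4n3Cc3cccc(C)c3)CC2)cc1`: 55.5%
- compound 2, `O=C(C1CC1)N1CCN(Cc2nc3ccccc3n2Cc2ccccc2C(F)(F)F)CC1`: 56.3%
- compound 3, `Cc1cccc(Cn2c(CN3CCN(C(=O)c4ccc(C(F)(F)F)cc4)CC3)nc3ccccc32)c1`: 22.9%

In an assay on isolated protein for inhibition of aldehyde dehydrogenase 1A1 (Homo sapiens), read by spectrophotometry, tested at 10 uM (a higher number here means more inhibition at the concentration tested (going by the name of the read-out), a lower number less inhibition), compound 3 gives the lowest of the three numbers. Its nearest neighbour is compound 1, and the one step shown, a number 32.6 percentage points lower from compound 1 to compound 3 (beyond the scatter), is beyond the scatter. Within the data shown here, compound 2, which carries a cyclopropyl on its carbonyl instead of a substituted phenyl, sits at a level close to that of compound 1; no single-point step connects it to compound 3, so its value stands on its own.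

The unmeasured compound 4, `Cc1cccc(Cn2c(CN3CCN(C(=O)C(C)C)CC3)nc3ccccc32)c1`, differs from compound 3 in one place: isopropyl in place of 4-(trifluoromethyl)phenyl on a carbonyl carbon. The step from compound 1 to compound 3 shows that the group on this carbonyl moves the read-out strongly, and compound 2 shows that a small saturated group on the carbonyl goes together with a number in the range of compound 1. The expectation for compound 4 is therefore a rise, a number 27.1 percentage points higher from compound 3 to compound 4 (beyond the scatter), in this assay. Compound 4 is estimated at 50%, with a range from 30% to 68%.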

Compound 4, a percentage reported as inhibition, at one concentration (the size of the read-out at that concentration, not a potency): 87.2%
Compound 4: middle estimate off by 37.2 percentage points, on the low side, and the stated range ends below it.
By their numbers in this assay, from the lowest: compound 3; then compounds 1 and 2 (each within the scatter of the next); then compound 4.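

In this assay, putting isopropyl in place of 4-(trifluoromethyl)phenyl on the carbonyl carbon gives a number 64.3 percentage points higher from compound 3 to compound 4 (beyond the scatter), so an aromatic ring on this carbonyl is not needed for a high number. Isopropyl in place of 4-methoxyphenyl at the same carbon gives a number 31.7 percentage points higher from compound 1 to compound 4 (beyond the scatter), which means that the earlier step, a comparison of two substituted phenyl groups, showed only part of the range this position can reach. Nothing among the data shown gives a reason for these rises.

On these data alone, whether a straight propyl chain, a tert-butyl group or a cyclopropyl would read as high as isopropyl on the core of compound 4 remains open. So does the effect of a longer chain, or of an amine attached directly to this carbonyl.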